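The source may report more compounds than this note shows. Statements on the series, on what has been measured and on what is new or still open speak of the compounds shown alone.

The measured compounds:
compound 1, `COc1ccc2nccc(C3CN(C4CCN(Cc5cc6ccccc6[nH]5)CC4)C(=O)O3)c2c1`: 25.1 nM
compound 2, `O=C1OC(c2ccnc3ccccc23)CN1C1CCN(Cc2cc3ccccc3[nH]2)CC1`: 1000 nM
compound 3, `O=C1OC(c2ccc3ccccc3n2)CN1C1CCN(Cc2cc3ccccc3[nH]2)CC1`: < 50200 nM

In an in vitro functional assay on RBL cells for antagonist activity at C-C chemokine receptor type 8 (Homo sapiens), read by FLIPR and calcium flux (on this read-out lower numbers stand for stronger inhibition and higher numbers for weaker inhibition), compound 1 gives the lowest of the two readable numbers; the nearest is compound 2, a 40-fold higher number from compound 1 to compound 2 (1.60 log units; beyond the scatter). For compound 3 the assay reports only a limit, < 50200 nM. Because of that limit the step that the limit leaves unreadable from compound 2 to compound 3 cannot be sized. Compound 4, `COc1ccc2nccc(C3CN(C4CCN(Cc5cccc(Cl)c5)CC4)C(=O)O3)c2c1`, differs from compound 1 in one place: 3-chlorophenyl in place of 1H-indol-2-yl on a saturated chain carbon bound to an amine nitrogen in a ring. Among the measured compounds shown here, no measured step touches this group: one alters the methoxy, the other the attachment of the quinoline, so nothing measured bears directly on the change. The expected step from compound 1 to compound 4 is therefore a cautious guess of some weakening, a 6.0-fold higher number from compound 1 to compound 4 (0.78 log units; beyond the scatter). In this assay compound 4 is expected to give 150 nM, within 20 nM to 2000 nM.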

Compound 4, half-maximal inhibitory concentration: 6310 nM
For compound 4 the middle estimate is 42-fold (1.62 log units) below the measured one; the whole stated range lies below it.
By their numbers in this assay, from the lowest: compound 1; then compound 2; then compound 4.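

Earlier steps altered only the methoxy and the quinoline attachment; this one shows that the group on a saturated chain carbon bound to an amine nitrogen in a ring also matters in this assay, where 3-chlorophenyl in place of 1H-indol-2-yl gives a 250-fold higher number from compound 1 to compound 4 (2.40 log units; beyond the scatter). The swap replaces two aromatic rings with one, loses the hydrogen-bond donor and adds chlorine, so this single step cannot separate these changes. Nothing measured here explains the loss.

Going by these compounds, how a plain benzyl or a 4-methoxybenzyl would read at this place remains open.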